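A few compounds are considered here, and "the series" means these few. Any claim that something is new, unique, unknown or untested is made for them only; others in the source may bear on it.

Series notes.

Compound 1 `Cc1ccsc1/C(=C/CCCCC(=O)O)c1cccnc1`: 29 nM
Compound 2 `CC(C)(CCCC/C=C(/c1ccccc1)c1cccnc1)C(=O)O`: 38 nM

In an assay (Equus caballus) for inhibition of Thromboxane-A synthase (Homo sapiens), using microsomes (on this read-out higher numbers stand for weaker inhibition and lower numbers for stronger inhibition), compound 1 gives the lowest of the two numbers, with compound 2 the nearest and within the scatter of it, so neither is called the stronger inhibitor. Compound 3 `O=C(O)CCCC/C=C(\c1cccnc1)c1ccccc1Br` is not yet measured; it differs from compound 1 by 2-bromophenyl in place of 3-methylthiophen-2-yl on a double-bonded chain carbon bound to an aromatic carbon and a double-bonded chain carbon. Going by the values given here, no measured pair isolates this change, so the step from compound 1 to compound 3 is expected to stay within the scatter, if anything toward a slightly higher number: a 1.2-fold higher number from compound 1 to compound 3 (0.08 log units; within the scatter). Compound 3 is estimated at 35 nM, with a range from 12 nM to 100 nM.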

Compound 3, half-maximal inhibitory concentration: 130 nM
Estimate against measurement, compound 3: 3.7-fold (0.57 log units) below; measured number above the stated range.
By their numbers in this assay, from the lowest: compounds 1 and 2 (each within the scatter of the next); then compound 3.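

In this assay the place on a double-bonded chain carbon bound to an aromatic carbon and a double-bonded chain carbon does not accept every aromatic group equally: 2-bromophenyl in place of 3-methylthiophen-2-yl gives a 4.5-fold higher number from compound 1 to compound 3 (0.65 log units; beyond the scatter) and so moves the number beyond the scatter, which compound 1 and compound 2 alone could not show.

Open, from the compounds shown here alone, is whether the bromine or the change of ring carries this step. 2-Methylphenyl or 2-chlorophenyl at this place would help separate the two, and for now no measured information explains the step.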